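The source may report more compounds than this note shows. Statements on the series, on what has been measured and on what is new or still open speak of the compounds shown alone.

Values measured in a functional assay on Mahlavu cells (Homo sapiens) for antiproliferative activity, read by sulforhodamine B assay, with a stated time of 72 h; on this read-out lower numbers stand for stronger inhibition and higher numbers for weaker inhibition:
- Compound 1 `Cc1ccc(N2CCN(c3ncnc4c3ncn4[C@@H]3O[C@H](CO)[C@@H](O)[C@H]3O)CC2)cc1`: > 100000 nM (a limit)
- Compound 2 `CC(C)c1ccc(Nc2ncnc3c2ncn3[C@@H]2O[C@H](CO)[C@@H](O)[C@H]2O)cc1`: 40000 nM
- Compound 3 `OC[C@H]1O[C@@H](n2cnc3c(NCCC4=CCCCC4)ncnc32)[C@H](O)[C@@H]1O`: > 100000 nM (a limit)

Compound 3 stands at the limit of > 100000 nM in this assay, at which 2 of the 3 values shown sit. Its true value is therefore not known, and compound 1 shares that limit. Only compound 2 has an actual number in this set.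

Compound 4 `OC[C@H]1O[C@@H](n2cnc3c(NCCC4=CCCCC4)nc(Cl)nc32)[C@H](O)[C@@H]1O` differs from compound 3 by one small change: chloro in place of hydrogen on an aromatic carbon. Chloro takes the place of hydrogen on an aromatic carbon, between two ring nitrogen atoms.

Within the data shown here, the only measured step is an at least 2.5-fold higher number from compound 2 to compound 3 (0.39 log units; beyond the scatter), where 2-(cyclohex-1-en-1-yl)ethyl replaces 4-isopropylphenyl on a nitrogen on an aromatic ring. Among the measured compounds shown here, that step lies at a different place in the molecule, and no measured pair shows what chloro does here. It bears on compound 4 only indirectly, by showing that a single change in this set can move the result across the limit.

For the measured compounds named here, with compound 2 at 40000 nM as the only number available, a modest gain for compound 4 is the most these data can support. Compound 4 may well meet the limit again.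

The expected step is an at least 1.4-fold lower number from compound 3 to compound 4 (0.15 log units; that floor lies within the scatter), small and towards a lower number if it can be seen at all.

For compound 4 the estimated value is 70000 nM, with an expected range from 25000 nM to 100000 nM.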

Compound 4, half-maximal inhibitory concentration: 30000 nM
Beside the measured number, compound 4's estimate is 2.3-fold (0.37 log units) above it, and the stated range covers the measured number.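

In this assay, a single chloro on the aromatic carbon between two ring nitrogen atoms gives an at least 3.3-fold lower number from compound 3 to compound 4 (0.52 log units; beyond the scatter). Among these compounds, this carbon carries hydrogen in all the earlier compounds, so this is the first sign that the result responds to a change at this position, with the 2-(cyclohex-1-en-1-yl)ethyl group on the amino nitrogen left untouched, and it gives compound 4 an actual number of 30000 nM. The size of the step is only a floor and its true size is unknown, since compound 3 has a limit and not a number: the limit of > 100000 nM in this assay, at which 2 of the 4 values shown sit.

The compounds shown leave open whether chloro is particular in this result or whether another group on the same carbon, such as fluoro, methoxy or an amine, would act alike. They also leave open whether chloro would change the result in the same direction with a different group on the amino nitrogen, such as the 4-isopropylphenyl group of compound 2.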